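A few compounds are considered here, and "the series" means these few. Any claim that something is new, unique, unknown or untested is made for them only; others in the source may bear on it.

Within the data shown here, in an ADME assay on the whole organism (Canis lupus familiaris, strain Beagle) for pharmacokinetics, read by LC-MS, with a stated time of 7 h (on this read-out lower numbers stand for slow clearance and higher numbers for fast clearance), three compounds have measured numbers so far. Compound 1 (`CNC(=O)c1cc(C(=O)N[C@H]2CC[C@H](O)CC2)c([C@@H](C)c2cccc(Cl)c2)o1`) gives 3.6 mL/min/kg, compound 3 (`CNC(=O)c1cc(C(=O)N[C@H]2[C@@H]3COC[C@@H]32)c([C@@H](C)c2ccccc2)o1`) gives 2.9 mL/min/kg, and compound 2 (`CNC(=O)c1cc(C(=O)N[C@H]2CC[C@H](O)CC2)n([C@@H](C)c2ccccc2)n1`) gives 1 mL/min/kg. Compound 2 therefore stands lowest of the three, and its gaps to both of the others lie beyond the usual scatter of repeated measurements. Among the measured compounds shown here, these three compounds differ in more than one place, so no measured pair shows what a single change does on its own.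

Compound 4 (`CNC(=O)c1cc(C(=O)N[C@H]2CC[C@H](OC)CC2)n([C@@H](C)c2ccccc2)n1`) is compound 2 with one change: methyl in place of hydrogen on an oxygen on a saturated carbon. A methyl takes the place of hydrogen on an oxygen on a saturated carbon, which turns 4-hydroxycyclohexyl into 4-methoxycyclohexyl. For the measured compounds named here, nothing measured so far tests this change directly, so any expectation has to be a loose one. Compound 2, at 1 mL/min/kg, already sits at the bottom of the measured numbers, which leaves more room for a rise than for a fall. The expected move in this assay is upward and modest, a 2.0-fold higher number from compound 2 to compound 4 (0.30 log units; within the scatter), and it may not clear the scatter. For compound 4 the estimate is 2 mL/min/kg, with an expected range from 0.8 mL/min/kg to 5 mL/min/kg.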

Compound 4, clearance in the Canis lupus familiaris assay: 6 mL/min/kg
Compound 4: middle estimate off by 3.0-fold (0.48 log units), on the low side; measured number above the stated range.
By their numbers in the Canis lupus familiaris assay, from the lowest: compound 2; then compounds 3, 1 and 4 (each within the scatter of the next, the first and the last beyond it).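

Among these compounds, the swap of hydroxy for methoxy on 4-hydroxycyclohexyl gives the first single-place comparison in this set, and in the Canis lupus familiaris assay it shows a 6.0-fold higher number from compound 2 to compound 4 (0.78 log units; beyond the scatter), a change that lies beyond the scatter even though only one methyl has been added, so this oxygen on the saturated ring carbon is a place where a small edit can shift clearance in dogs, at least for this pair. In a physicochemical assay for solubility (on this read-out lower numbers stand for lower solubility and higher numbers for higher solubility), compound 2 gives >= 180 ug/mL, which is a limit of the assay and not a number. In the physicochemical assay compound 4 gives >= 161 ug/mL, again a limit of the assay and not a number, so the solubility step for this change cannot be read.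

The data shown offer nothing that explains the rise in clearance. From the compounds shown here alone, it also stays open whether this step belongs to the methyl alone or would recur with a longer chain such as ethyl on the same oxygen, with an amine in place of the hydroxy, or with the same swap on the core of compound 1.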